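Triazole series: aryl swap on the ring nitrogen

A few compounds are considered here, and "the series" means these few. Any claim that something is new, unique, unknown or untested is made for them only; others in the source may bear on it.

Measured so far:
compound 1, `CC(C)(C)c1ccc(-n2nc(-c3ccc(C(F)(F)F)cc3O)nc2-c2ccccc2O)cc1`, 77.8%
compound 2, `Oc1cc(C(F)(F)F)ccc1-c1nc(-c2ccccc2O)n(-c2ccc(Cl)cc2)n1`, 87.3%

Both compounds carry the same core, with the two hydroxyphenyl groups fixed and only the aryl group on the ring nitrogen varied. In a functional assay on PC-12 cells (Rattus norvegicus) for cytotoxicity, read by MTT assay, with stated times of 2 h and 24 h, tested at 5 uM (on this read-out higher numbers stand for a stronger effect at the one concentration tested and lower numbers for a weaker effect), compound 1 gives 77.8%, and compound 2 gives 87.3%. Among the compounds with values here, the single step measured, a number 9.5 percentage points higher from compound 1 to compound 2 (within the scatter), is within the scatter, so the two numbers do not separate, and compound 2 cannot be set apart from compound 1 on this read-out.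

Compound 3, `COc1cccc(-n2nc(-c3ccc(C(F)(F)F)cc3O)nc2-c2ccccc2O)c1`, is the next member and has not yet been measured in this assay. Relative to compound 2 the change is 3-methoxyphenyl in place of 4-chlorophenyl on an aromatic nitrogen. Within the data shown here, the only step that bears on it is the one at the same aryl group, a number 9.5 percentage points higher from compound 1 to compound 2 (within the scatter), which stayed within the scatter. With nothing more to go on, no step beyond the scatter is expected here, in either direction.

For compound 3 the expected value in this assay is 82%, with a range from 65% to 95%. This estimate amounts to a step of a number 5.3 percentage points lower from compound 2 to compound 3 (within the scatter), which is expected to stay within the scatter.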

Compound 3, a percentage reported as activity, at one concentration (the size of the read-out at that concentration, not a potency): 96.8%
Compound 3: middle estimate off by 14.8 percentage points, on the low side; the whole stated range lies below it.
By their numbers in this assay, from the lowest: compounds 1, 2 and 3 (each within the scatter of the next, the first and the last beyond it).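

In this assay, within the data shown here, the aryl group on the ring nitrogen now gives the first step beyond the scatter: a number 19 percentage points higher from compound 1 to compound 3 (beyond the scatter) with 3-methoxyphenyl in place of 4-(tert-butyl)phenyl, which shows that a change at this position can register on this read-out, if only modestly. The other new step, a number 9.5 percentage points higher from compound 2 to compound 3 (within the scatter) with 3-methoxyphenyl in place of 4-chlorophenyl, does not separate those two groups, and compound 2 also stays unseparated from compound 1, so only the two ends of the series part. Nothing available on these compounds beyond this one read-out offers an explanation for the separation.

The substituent and its printed ring number change together in 3-methoxyphenyl, so 4-methoxyphenyl and 3-chlorophenyl would be needed to tell apart what each contributes. Also open, from the compounds shown here alone, is how a phenyl group carrying an amine or a carboxylic acid would read here, and whether the separation holds at concentrations other than the single one tested.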